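This account rests on a few compounds, and the source may have more. Where it says the series, first, only, none or still open, it means among the compounds named here.

In a functional assay on KB 3-1 cells (Homo sapiens) for cytotoxicity, read by MTT assay, with a stated time of 68 h (on this read-out lower numbers stand for stronger inhibition and higher numbers for weaker inhibition), compound 2 `Cc1ccccc1-c1cccc(NC(=O)C(Cl)Cl)c1` gives 42000 nM while compound 1 `O=C(Nc1cccc(-c2ccccc2C(F)(F)F)c1)C(Cl)Cl` gives 35900 nM and the two numbers cannot be told apart. Compound 3 `O=C(Nc1cccc(-c2ccccc2F)c1)C(Cl)Cl` carries one change from compound 2: fluoro in place of methyl on an aromatic carbon on a six-membered aromatic ring of carbon only. Just one measured step bears on this swap, and it is a 1.2-fold higher number from compound 1 to compound 2 (0.07 log units; within the scatter) with methyl in place of trifluoromethyl in that same place. Exchanging one group there for another has so far left the number within the scatter. A single step is thin evidence, but no step beyond the scatter is expected in this assay for the new swap. The expected outcome is a 1.1-fold lower number from compound 2 to compound 3 (0.02 log units; within the scatter) as an estimate only. For compound 3 the estimated value is 40000 nM with an expected range from 20000 nM to 80000 nM in repeat measurements.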

Compound 3, half-maximal inhibitory concentration: 48300 nM
For compound 3 the middle estimate is 1.2-fold (0.08 log units) below the measured one; the measured number falls inside the stated range.
By their numbers in this assay, from the lowest: compounds 1, 2 and 3 (each within the scatter of the next).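

In this assay, the group on this aromatic carbon, ortho to a large group, has now been exchanged in a second and third pairing, and both new steps lie within the scatter: fluoro in place of methyl gives a 1.2-fold higher number from compound 2 to compound 3 (0.06 log units; within the scatter) and fluoro in place of trifluoromethyl gives a 1.3-fold higher number from compound 1 to compound 3 (0.13 log units; within the scatter) as its result. The earlier compounds shown here compared only methyl with trifluoromethyl, whereas fluoro now joins them, and the three groups cannot be told apart at this place in this read-out. Nothing in the data shown accounts for this flat picture.

On these data alone, it remains open whether a group of another kind at this place, such as an amine, a carboxylic acid or a longer chain, would move the number beyond the scatter. As far as these compounds go, it is also open whether fluoro on another carbon of this ring would leave the number just as unchanged.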